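Para substituent swap on the benzyl ring: methyl to fluoro

A few compounds are considered here, and "the series" means these few. Any claim that something is new, unique, unknown or untested is made for them only; others in the source may bear on it.

In a functional assay on PC-3 cells (Homo sapiens) for antiproliferative activity, read by MTT assay, with a stated time of 48 h (a lower number here means a stronger inhibitor, a higher number a weaker inhibitor), compound 1 `Brc1ccc(Cn2cc(CSc3nnc(-c4ccccc4)c(-c4ccccc4)n3)nn2)cc1` gives 22000 nM, and compound 2 `Cc1ccc(Cn2cc(CSc3nnc(-c4ccccc4)c(-c4ccccc4)n3)nn2)cc1` gives 22600 nM. The step of a 1.0-fold higher number from compound 1 to compound 2 (0.01 log units; within the scatter) is the only one measured so far; compound 2 stands within the scatter of compound 1, so neither compound is distinguished. Compound 3 `Fc1ccc(Cn2cc(CSc3nnc(-c4ccccc4)c(-c4ccccc4)n3)nn2)cc1` differs from compound 2 by fluoro in place of methyl on an aromatic carbon. Going by the values given here, the one known step at this position lies within the scatter, so for compound 3 no step beyond the scatter is expected, a 1.0-fold lower number from compound 2 to compound 3 (0.01 log units; within the scatter). In this assay compound 3 is estimated at 22000 nM, with a range from 11000 nM to 45000 nM.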

Compound 3, half-maximal inhibitory concentration: 10600 nM
The estimate for compound 3 lay 2.1-fold (0.32 log units) above the measured number, and the stated range ends above it.
By their numbers in this assay, from the lowest: compound 3; then compounds 1 and 2 (each within the scatter of the next).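

At this position, this assay does respond to the group: fluoro in place of methyl gives a 2.1-fold lower number from compound 2 to compound 3 (0.33 log units; beyond the scatter) and fluoro in place of bromo gives a 2.1-fold lower number from compound 1 to compound 3 (0.32 log units; beyond the scatter) as well, both modest. Methyl and bromo did not separate, so the position looked indifferent until fluoro entered, and compound 3 now stands apart from compound 1 and compound 2. No available data account for this difference.

Going by these compounds, whether a methoxy group, an amine or a carboxylic acid here would fall below or above compound 3 remains open. So does whether any group at this position can give more than a modest step.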